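The source may report more compounds than this note shows. Statements on the series, on what has been measured and on what is new or still open speak of the compounds shown alone.

Among the measured compounds shown here, in a functional assay on LoVo cells (Homo sapiens) for inhibition, read by colorimetric assay and MTT assay, with a stated time of 72 h (on this read-out lower numbers stand for stronger inhibition and higher numbers for weaker inhibition), three compounds have numbers so far. Compound 1 `Cc1ccc2c(c1)-c1cnc(n1C)OCCCCCCCCO2` gives 34000 nM, compound 2 `Cn1c2cnc1OCCCCCCCCOc1cc3ccccc3cc1-2` gives 16000 nM, and compound 3 `C=CCCCCOc1ccccc1-c1cnc(OCCC=C)n1C` gives 12000 nM. Compound 3 therefore sits level with compound 2, within the usual scatter, while its number is lower than that of compound 1 by more than the scatter. Compound 4 `C=CCCCCOc1ccc(F)cc1-c1cnc(OCCC=C)n1C` differs from compound 3 in one place: fluoro in place of hydrogen on an aromatic carbon, para to a (hex-5-en-1-yl)oxy group. For the measured compounds named here, no measured pair shows what such a swap does, so no change beyond the scatter is expected in this assay, in either direction. The expected step, a 1.2-fold lower number from compound 3 to compound 4 (0.08 log units; within the scatter), stays within the scatter. For compound 4 the estimated value is 10000 nM, with an expected range from 5000 nM to 20000 nM.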

Compound 4, half-maximal inhibitory concentration: 38000 nM
Compound 4: the middle estimate sits 3.8-fold (0.58 log units) below what was measured; the measured number lies above the stated range.
By their numbers in this assay, from the lowest: compounds 3 and 2 (each within the scatter of the next); then compounds 1 and 4 (each within the scatter of the next).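

In this assay fluoro in place of hydrogen on an aromatic carbon, para to a (hex-5-en-1-yl)oxy group, gives a 3.2-fold higher number from compound 3 to compound 4 (0.50 log units; beyond the scatter) and so weakens inhibition by more than the scatter. Among the compounds shown here, this is the first comparison here of compounds that differ in one place, and it shows that this position responds to a change of a single atom. No measurement at hand explains the step. From the compounds shown here alone, whether the loss belongs to fluoro alone stays open, as no chloro, methoxy or amine group appears at this carbon. Going by these compounds, the effect of fluoro elsewhere on the aromatic ring also remains unknown.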